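The compounds below may be only part of what the source reports. "The series", "measured", "known", "first", "only" and "open" are said of these compounds alone.

Measured in a functional assay on HL-60 cells (Homo sapiens) for inhibition, read by MTT assay, with a stated time of 72 h; a lower number here means a stronger inhibitor, a higher number a weaker inhibitor:
- compound 1 `Cc1nc(-c2ccccc2)c(C(=O)N2CCN(c3c(C)cccc3C)CC2)o1`: 146 nM
- compound 2 `Cc1nc(-c2ccccc2)c(C(=O)N2CCN(c3cccc(F)c3)CC2)o1`: 45 nM

Compound 2 holds the lower of the two numbers, making it the stronger inhibitor so far. Compound 3 `Cc1nc(-c2ccccc2)c(C(=O)N2CCN(c3ccc(C)c(C)c3)CC2)o1` has 3,4-dimethylphenyl in place of the 3-fluorophenyl of compound 2, on an amine nitrogen in a ring (3,4-dimethylphenyl in place of 3-fluorophenyl on an amine nitrogen in a ring). Within the data shown here, only one measured step bears on this change: a 3.2-fold lower number from compound 1 to compound 2 (0.51 log units; beyond the scatter), where 3-fluorophenyl replaced 2,6-dimethylphenyl at the same place. A different dimethylphenyl group is not the same change, so this is only a rough guide. A modest rise in the number is expected, a 2.0-fold higher number from compound 2 to compound 3 (0.30 log units; within the scatter). The estimate for compound 3 is 90 nM, with an expected range of 35 nM to 230 nM.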

Compound 3, half-maximal inhibitory concentration: 43 nM
Estimate against measurement, compound 3: 2.1-fold (0.32 log units) above, within the range that was stated.
By their numbers in this assay, from the lowest: compounds 3 and 2 (each within the scatter of the next); then compound 1.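

Swapping 3-fluorophenyl for 3,4-dimethylphenyl on the ring nitrogen gives a 1.0-fold lower number from compound 2 to compound 3 (0.02 log units; within the scatter) and so leaves the number within the scatter: this place accepts a phenyl ring carrying two methyl groups as well as one carrying fluorine. The two dimethylphenyl groups do differ, with a 3.4-fold lower number from compound 1 to compound 3 (0.53 log units; beyond the scatter) for the change from 2,6-dimethylphenyl to 3,4-dimethylphenyl, so the same two methyl groups, placed differently on the ring, change the number. Nothing measured here explains either step. From the compounds shown here alone, what an amine or a carboxylic acid on this phenyl ring would do to the number stays open.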